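The compounds below may be only part of what the source reports. "The series", "measured", "known", "first", "only" and "open" are said of these compounds alone.

Among the measured compounds shown here, compound 1 `CN1C(=S)[C@@H](NC(=O)c2nc(Cc3ccccc3)n(CCCO)n2)COc2ccccc21` gives 209 nM in a functional assay on HT-29 cells (Homo sapiens) for inhibition, read by luminescence and CellTiter-Glo, with a stated time of 24 h (on this read-out higher numbers stand for an effect only at larger amounts of compound and lower numbers for an effect already at smaller amounts), and stands lowest of the two numbers so far. Compound 2 `CN1C(=S)[C@@H](NC(=O)c2nc(Cc3ccccc3)n(C3CCCCCC3)n2)COc2ccccc21` gives 5530 nM in this assay; the step is a 26-fold higher number from compound 1 to compound 2 (1.42 log units; beyond the scatter). Compound 3 `CN1C(=S)[C@@H](NC(=O)c2nc(Cc3ccccc3)n(CC3COC3)n2)COc2ccccc21` is still unmeasured and differs from compound 1 by oxetan-3-yl in place of 2-hydroxyethyl on a saturated chain carbon bound to an aromatic nitrogen. For the measured compounds named here, the single measured step bears only loosely on this change: it exchanged 3-hydroxypropyl for cycloheptyl and was large. Here the hydrogen-bond donor is likewise lost, but the entering oxetan-3-yl keeps one hydrogen-bond acceptor. A rise clearly smaller than that step is therefore expected. Compound 3 is expected at 600 nM, within 200 nM to 2000 nM. The estimate amounts to a 2.9-fold higher number from compound 1 to compound 3 (0.46 log units; beyond the scatter).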

Compound 3, half-maximal effective concentration: 2830 nM
Estimate against measurement, compound 3: 4.7-fold (0.67 log units) below; measured number outside the range, above it.
By their numbers in this assay, from the lowest: compound 1; then compounds 3 and 2 (each within the scatter of the next).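

In this assay, (oxetan-3-yl)methyl in place of 3-hydroxypropyl gives a 14-fold higher number from compound 1 to compound 3 (1.13 log units; beyond the scatter), so keeping a hydrogen-bond acceptor while losing the donor does not preserve the number of compound 1. The step of a 2.0-fold lower number from compound 2 to compound 3 (0.29 log units; within the scatter) leaves the oxygen-bearing oxetane and the all-carbon cycloheptyl not separated. No measurement on offer accounts for this result.

Going by these compounds, whether the free hydroxyl itself is what matters stays open, and 3-methoxypropyl would test that directly. Also open, on these data alone, is how a 3-aminopropyl group or a longer chain such as 4-hydroxybutyl would read at this nitrogen.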